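This account rests on a few compounds, and the source may have more. Where it says the series, first, only, none or still open, it means among the compounds named here.

The three measured compounds, each tested in a functional assay on L1210 cells (Mus musculus) for inhibition, read by cell counting, with a stated time of 2 days; a lower number here means a stronger inhibitor, a higher number a weaker inhibitor:
Compound 1 `Nc1cccc(-c2cn3nc(-c4ccc(F)cc4)sc3n2)c1` gives >= 250000 nM, which is a limit of the assay rather than a number.
Compound 2 `Nc1cccc(-c2cn3nc(Cc4ccccc4)sc3n2)c1` gives 7400 nM.
Compound 3 `C=C(Br)C(=O)Nc1cccc(-c2cn3nc(-c4cccs4)sc3n2)c1` gives 170 nM.

Compound 3 has the lowest number among the three, with compound 2 as its nearest neighbour on the scale. Compound 4 `Nc1cccc(-c2cn3nc(-c4cccs4)sc3n2)c1` is not yet measured; it differs from compound 3 in one place: hydrogen in place of (1-bromoethenyl)carbonyl on a nitrogen on an aromatic ring. No measured step covers this change, since the only step shown, an at least 33-fold lower number from compound 1 to compound 2 (1.52 log units; beyond the scatter), concerns the group on an aromatic carbon and leaves the amino group untouched. What the shown numbers do offer is that both compounds carrying a plain amino group, compound 1 and compound 2, sit far higher on the scale than compound 3, one of them at a limit (the limit of >= 250000 nM in this assay, at which 1 of the 3 values shown sits). On that basis a large move towards weaker inhibition is expected for compound 4, of the size a 71-fold higher number from compound 3 to compound 4 (1.85 log units; beyond the scatter). The estimate for compound 4 in this assay is 12000 nM, with a range from 2000 nM to 100000 nM.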

Compound 4, half-maximal inhibitory concentration: > 250000 nM
Compound 4 was reported as a limit (the forecaster's own chance of this, stated with the estimate: 20%); at least 20-fold (1.31 log units) between middle value and limit.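

With the thiophen-2-yl group held fixed, replacing (1-bromoethenyl)carbonyl on the nitrogen with hydrogen gives an at least 1400-fold higher number from compound 3 to compound 4 (3.16 log units; beyond the scatter), so in this assay the inhibition seen with compound 3 depends strongly on this group. Compound 4 stands at a limit of the assay, not at a number: the limit of > 250000 nM in this assay, at which 1 of the 4 values shown sits. With the amino group kept, the group on the aromatic carbon also matters, as thiophen-2-yl in place of benzyl gives an at least 33-fold higher number from compound 2 to compound 4 (1.52 log units; beyond the scatter), so compound 2 keeps measurable inhibition without the (1-bromoethenyl)carbonyl group, while the step from compound 1 to compound 4 cannot be read.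

On these data alone, it remains open whether the whole (1-bromoethenyl)carbonyl group is needed, or whether a simple acetyl or an acryloyl group on the same nitrogen would serve as well. As far as these compounds go, it is also open whether the (1-bromoethenyl)carbonyl group would have a similar effect alongside benzyl or 4-fluorophenyl.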